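Swapping an isopropyl for a hydroxy on a shared core

A few compounds are considered here, and "the series" means these few. Any claim that something is new, unique, unknown or untested is made for them only; others in the source may bear on it.

Measured so far:
compound 1, `CC(C)c1ccc(NC2=NCCC3(CCCCC3)S2)cc1`, 1.57
compound 2, `Fc1ccc(NC2=NCCC3(CCCCC3)S2)cc1Cl`, 2.03

In a physicochemical assay for lipophilicity, measured as octanol-water partition, at pH 7.4 (a higher number here means a more lipophilic compound, a lower number a more polar compound), compound 1 gives 1.57, the lower of the two numbers, with compound 2 standing higher by an amount beyond the usual scatter. Compound 3, `Oc1ccc(NC2=NCCC3(CCCCC3)S2)cc1`, has not yet been measured. It differs from compound 1 in one place: hydroxy in place of isopropyl on an aromatic carbon. Within the data shown here, no measured pair shows this change, so the expectation rests on the change itself. A step downward, clearly beyond the scatter, is expected, of about a number 2.07 log units lower from compound 1 to compound 3 (beyond the scatter) in this assay. Compound 3 is therefore estimated at -0.5, within a range from -1.3 to 0.3.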

Compound 3, distribution coefficient: 1.96
Estimate against measurement, compound 3: 2.46 log units below; the whole stated range lies below it.
By their numbers in this assay, from the lowest: compound 1; then compounds 3 and 2 (each within the scatter of the next).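

Hydroxy in place of isopropyl on an aromatic carbon, para to a large group, gives a number 0.39 log units higher from compound 1 to compound 3 (beyond the scatter) in this assay and is the first single-place change read on the shared core. At this position, then, the change raises the number by a modest step rather than lowering it. Nothing at hand accounts for this direction.

From the compounds shown here alone, whether an amine or a methoxy group at the same position would also raise the number stays open. So does whether the same change would give a similar step on a different core.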